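The source may report more compounds than this note shows. Statements on the series, on what has been measured and on what is new or still open speak of the compounds shown alone.

Measured so far:
- Compound 1 `C=C[C@@](C)(/C=C/c1ccc(O)c(/C=C/C#N)c1)CCC=C(C)C`: > 43400 nM (a limit)
- Compound 2 `C=C[C@@](C)(/C=C/c1ccc(O)c(/C=C/C(=O)O)c1)CCC=C(C)C`: > 43400 nM (a limit)

In a functional assay on NALM-6 cells (Homo sapiens) for cytotoxicity, with a stated time of 72 h (on this read-out lower numbers stand for an effect already at smaller amounts and higher numbers for an effect only at larger amounts of compound), compound 2 gives > 43400 nM, which is a limit of the assay and not a number. Compound 1 also gives only a limit, > 43400 nM. Among the compounds with values here, the sole measured step bearing on the change is a step that the two limits leave unreadable from compound 1 to compound 2, so it supplies no size to carry over. All that the series shows is the limit of > 43400 nM in this assay, at which 2 of the 2 values shown sit.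

Compound 3 `C=C[C@@](C)(/C=C/c1ccc(O)c(/C=C/c2ccc(Cl)c(Cl)c2)c1)CCC=C(C)C` follows from compound 2 by one change: 3,4-dichlorophenyl in place of carboxy on a double-bonded chain carbon bound to a double-bonded chain carbon. This group is unlike both the cyano of compound 1 and the carboxy of compound 2, so a move in this assay toward lower numbers is expected, with its size weakly founded. The expected step is an at least 2.1-fold lower number from compound 2 to compound 3 (0.33 log units; beyond the scatter). For compound 3 the estimated value is 20000 nM, with an expected range of 5000 nM to 60000 nM.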

Compound 3, half-maximal effective concentration: 7510 nM
Compound 3: the middle estimate sits 2.7-fold (0.43 log units) above what was measured; measured number inside the range.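

At this place, on a double-bonded chain carbon bound to a double-bonded chain carbon, 3,4-dichlorophenyl gives the only read-out in this assay that is a number and not a limit: compound 3 gives 7510 nM. Set against the carboxy group the change is an at least 5.7-fold lower number from compound 2 to compound 3 (0.76 log units; beyond the scatter), and set against the cyano group it is an at least 5.7-fold lower number from compound 1 to compound 3 (0.76 log units; beyond the scatter); both sizes are lower bounds only. The position thus responds to the group it carries, although the step between compound 1 and compound 2 cannot be read and the values of both remain limits of the assay: the limit of > 43400 nM in this assay, at which 2 of the 3 values shown sit.

Going by these compounds, whether the change rests on the aromatic ring or on its chlorine atoms stays open, and a plain phenyl group at this place would separate the two. Also open, on these data alone, is how a basic amine on the same chain would read.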